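Ester in place of ether on the side-chain oxygen

The source may report more compounds than this note shows. Statements on the series, on what has been measured and on what is new or still open speak of the compounds shown alone.

Compound 1 `COCc1c(C)nc2c(OCc3ccccc3)cccn12` holds the highest number of the three measured compounds: in a functional assay on the whole organism (stomach) for inhibition, with Canis familiaris (Canis lupus familiaris) as the target, at a dose of 5 mg/kg by the intravenous route (a higher number here means a stronger effect of the compound at the dose given, a lower number a weaker effect), compound 1 gives 29%, compound 2 `CCSCc1c(C)nc2c(OCc3ccccc3)cccn12` gives 0% and compound 3 `Cc1nc2c(OCc3ccccc3)cccn2c1C[S+](C)[O-]` gives 18%. Both replacements of the methoxy group lowered the read-out, a number 29 percentage points lower from compound 1 to compound 2 (beyond the scatter) and a number 11 percentage points lower from compound 1 to compound 3 (beyond the scatter), while a number 18 percentage points higher from compound 2 to compound 3 (beyond the scatter) separates the two sulfur compounds. Compound 4 `CCCCC(=O)OCc1c(C)nc2c(OCc3ccccc3)cccn12` differs from compound 1 by butylcarbonyl in place of methyl on an oxygen on a saturated carbon. Going by the values given here, no measured step changes the group on the oxygen itself; the two steps that leave compound 1 each exchange the whole methoxy group, and both fall. For compound 4 a modest fall, or no step beyond the scatter, is therefore expected, a number 11 percentage points lower from compound 1 to compound 4 (beyond the scatter). The estimate for compound 4 is 18%, within 0% to 40%.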

Compound 4, a percentage reported as inhibition, in the whole organism at one dose (the size of the read-out at that dose, not a potency): 96%
Estimate against measurement, compound 4: 78 percentage points below; measured number above the stated range.
By their numbers in this assay, from the lowest: compound 2; then compound 3; then compound 1; then compound 4.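

In this assay, the group on the oxygen on a saturated carbon can move the read-out strongly upward: butylcarbonyl in place of methyl gives a number 67 percentage points higher from compound 1 to compound 4 (beyond the scatter), whereas both earlier exchanges of the methoxy group lowered it. The (butylcarbonyl)oxy group also stands well clear of the two sulfur side chains, with a number 78 percentage points higher from compound 3 to compound 4 (beyond the scatter) and a number 96 percentage points higher from compound 2 to compound 4 (beyond the scatter). Nothing available on these compounds explains the rise. On these data alone, it remains open whether the carbonyl or the chain carries this rise; an acetyl group or a plain pentyl group on the same oxygen would separate the two.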